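A few compounds are considered here, and "the series" means these few. Any claim that something is new, unique, unknown or untested is made for them only; others in the source may bear on it.

In an ADME assay on MCF7 cells (Homo sapiens) for cytotoxicity, read by MTT assay, with a stated time of 48 h (on this read-out higher numbers stand for weaker inhibition and lower numbers for stronger inhibition), compound 1 (`C=C1[C@H](OC(C)=O)[C@H]2[C@@H](OC(=O)c3ccccc3)[C@@H](C)C[C@]2(OC(C)=O)C(=O)[C@@H](C)/C=C/C(C)(C)C(=O)[C@H](OC(C)=O)[C@H]1OC(C)=O`) gives > 100000 nM as a limit of the assay and not a number. Compound 2 (`C=C1[C@H](O)[C@H]2[C@@H](OC(=O)c3ccccc3)[C@](C)(OC(C)=O)C[C@]2(O)[C@H](OC(C)=O)[C@@H](C)/C=C/C(C)(C)C(=O)[C@H](OC(C)=O)[C@H]1OC(C)=O`) gives > 100000 nM as a limit too. Compound 3 (`C=C1[C@H](O)[C@H]2[C@@H](OC(=O)c3ccccc3)[C@](C)(O)C[C@]2(O)[C@H](OC(C)=O)[C@@H](C)/C=C/C(C)(C)C(=O)[C@H](OC(C)=O)[C@H]1OC(=O)c1ccccc1`) gives > 100000 nM as a limit too. Compound 1 thus stands at the limit of > 100000 nM in this assay, at which 3 of the 3 values shown sit, and no graded step can be read from the three. Compound 4 (`C=C1[C@H](OC(C)=O)CC(=O)C(C)(C)/C=C/[C@H](C)C(=O)[C@@]2(OC(C)=O)C[C@H](C)[C@H](OC(=O)c3ccccc3)[C@@H]2[C@H]1OC(C)=O`) departs from compound 1 by one change, hydrogen in place of acetoxy on a saturated ring carbon in words hydrogen in place of acetoxy on a saturated ring carbon. In this assay no step beyond the scatter is expected, with inhibition staying weak. The expected change is a number no higher from compound 1 to compound 4 (the limit leaves the size open) and no more. Compound 4 is expected at 100000 nM within an estimated range from 40000 nM to 200000 nM in this assay.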

Compound 4, half-maximal inhibitory concentration: 51100 nM
Compound 4: the middle estimate sits 2.0-fold (0.29 log units) above what was measured; measured number inside the range.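

Within the data shown here, compound 4 is the only compound here to give a number rather than a limit of the assay in this assay. Hydrogen in place of acetoxy on this saturated ring carbon gives an at least 1.9-fold lower number from compound 1 to compound 4 (0.29 log units; that floor lies within the scatter), so the position tolerates losing the acetoxy, but the true size of the step stays unknown. The remaining values offer no graded comparison: the limit of > 100000 nM in this assay, at which 3 of the 4 values shown sit.

The compounds shown leave open whether an amine or a longer ester chain on this ring carbon would also give a number. They also leave open whether the same change would do so on the cores of compound 2 and compound 3.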